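From a bromophenyl amide to a furan amide

This account rests on a few compounds, and the source may have more. Where it says the series, first, only, none or still open, it means among the compounds named here.

The series rests on a shared core carrying an amide. Compound 1 `CCN1CCN(c2cc(C)c3cc(NC(=O)c4ccccc4C)ccc3n2)CC1` bears a 2-methylphenyl on the carbonyl carbon and in a functional assay on SK-BR-3 cells (Homo sapiens) for antiproliferative activity, read by MTT assay, with a stated time of 72 h (on this read-out lower numbers stand for stronger inhibition and higher numbers for weaker inhibition), compound 1 gives 29200 nM. Compound 2 `CCN1CCN(c2cc(C)c3cc(NC(=O)c4cccc(Br)c4)ccc3n2)CC1` carries a 3-bromophenyl in that place and in this assay compound 2 gives 13300 nM. The only measured step is a 2.2-fold lower number from compound 1 to compound 2 (0.34 log units; beyond the scatter), so compound 2 holds the lowest of the two numbers shown.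

The next compound, compound 3 `CCN1CCN(c2cc(C)c3cc(NC(=O)c4ccco4)ccc3n2)CC1`, changes the aryl group again: furan-2-yl in place of 3-bromophenyl on a carbonyl carbon. Among the measured compounds shown here, the one measured step, from compound 1 to compound 2, exchanged one six-membered aromatic ring of carbon only for another and was modest; it does not speak directly to a five-membered aromatic ring with an oxygen entering in place of a 3-bromophenyl. For the measured compounds named here, with no step of this kind measured, the step from compound 2 to compound 3 is expected to stay within the scatter, a 1.4-fold higher number from compound 2 to compound 3 (0.13 log units; within the scatter), and the estimate for compound 3 in this assay is 18000 nM, within a range of 6000 nM to 50000 nM.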

Compound 3, half-maximal inhibitory concentration: 37500 nM
Estimate against measurement, compound 3: 2.1-fold (0.32 log units) below; the range from low to high includes it.
By their numbers in this assay, from the lowest: compound 2; then compounds 1 and 3 (each within the scatter of the next).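

In this assay, the group on this carbonyl carbon can move the number in either direction: the 3-bromophenyl of compound 2 was reached with a lower number, and furan-2-yl in its place gives a 2.8-fold higher number from compound 2 to compound 3 (0.45 log units; beyond the scatter). The five-membered ring does not separate from the 2-methylphenyl of compound 1, with a 1.3-fold higher number from compound 1 to compound 3 (0.11 log units; within the scatter), so only compound 2 stands apart from the other two, and a ring of either size can give a number in the same range. Nothing available explains why the 3-bromophenyl differs from the furan-2-yl at this position.

The three compounds leave open whether the difference follows the bromine, the ring that carries it, or both, since the bromine and the six-membered ring leave together in the step to the furan. As far as these compounds go, how a plain phenyl, a thiophene or a pyridine ring would stand at this carbonyl carbon remains open, as does whether any group here could bring the number far below that of compound 2.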